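This account rests on a few compounds, and the source may have more. Where it says the series, first, only, none or still open, it means among the compounds named here.

Compound 1 `NC(CO)(CO)CCCCCCCCCCc1ccccc1`: 0.3 mg/kg
Compound 2 `CCCCCCCCCc1ccc(CCC(N)(CO)CO)cc1`: 0.03 mg/kg

Both were tested in a functional assay on the whole organism with Rattus norvegicus as the target; a lower number here means that less compound is needed, a higher number that more compound is needed for the effect. Compound 2 gives 0.03 mg/kg, the lower of the two numbers, so less of it is needed for the effect than of compound 1, whose result of 0.3 mg/kg is higher by more than the usual scatter of this kind of measurement. Compound 3 `CCCCCCCCCCCc1ccc(CCC(N)(CO)CO)cc1` has not yet been measured in this assay. It differs from compound 2 in one place: ethyl in place of hydrogen on a saturated chain carbon, nine bonds along the chain from an aromatic carbon. Within the data shown here, no pair of measured compounds shows what ethyl in place of hydrogen on a saturated chain carbon does here, so the expectation rests on compound 2 alone. The expected step, a 1.7-fold higher number from compound 2 to compound 3 (0.22 log units; within the scatter), is a small rise in dose, about at the edge of the scatter, with the direction uncertain. For compound 3 the estimate in this assay is 0.05 mg/kg, expected to fall between 0.01 mg/kg and 0.3 mg/kg.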

Compound 3, dose for 50% inhibition: 0.1 mg/kg
For compound 3 the middle estimate is 2.0-fold (0.30 log units) below the measured one; measured number inside the range.
By their numbers in this assay, from the lowest: compound 2; then compound 3; then compound 1.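

Among these compounds, this is the first reading of what happens at this position in this assay: ethyl in place of hydrogen on a saturated chain carbon, nine bonds along the chain from an aromatic carbon, gives a 3.3-fold higher number from compound 2 to compound 3 (0.52 log units; beyond the scatter). The position is therefore not indifferent to this change, and here the longer chain needs more compound for the effect, though the step is modest. Nothing available explains why the dose rises.

Going by these compounds, whether methyl in place of hydrogen at this position moves the number the same way, and whether a hydroxyl or a carboxylic acid there would behave like ethyl, remains open. A single step also cannot show whether a still longer chain would continue this rise or reverse it.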